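Furan carboxamide series: exchange of the amide-side cyclohexyl group

This account rests on a few compounds, and the source may have more. Where it says the series, first, only, none or still open, it means among the compounds named here.

Two compounds of this series carry a shared core with an amide-bearing furan. Compound 1 `CCOC(=O)[C@H]1CC[C@H](CNC(=O)c2ccc(Cc3cc4c(cc3C)C(C)(C)CCC4(C)C)o2)CC1` gives 2730 nM in an assay on isolated protein for binding affinity to Gonadotropin-releasing hormone receptor (Rattus norvegicus) (on this read-out higher numbers stand for weaker inhibition and lower numbers for stronger inhibition), the higher of the two numbers recorded. Compound 2 `Cc1cc2c(cc1Cc1ccc(C(=O)NCC3CCC(CNCc4c(C)noc4C)CC3)o1)C(C)(C)CCC2(C)C` gives 1200 nM in this assay, and the gap between compound 1 and compound 2 lies beyond the scatter of repeated measurements.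

Compound 3 `Cc1cc2c(cc1Cc1ccc(C(=O)NCC3CCN(C(=N)N)CC3)o1)C(C)(C)CCC2(C)C` has not been measured. It differs from compound 1 by a group of 9 heavy atoms (6 carbon, 3 nitrogen; one six-membered non-aromatic ring with 1 hetero atom) in place of a group of 11 heavy atoms (9 carbon, 2 oxygen; one six-membered non-aromatic ring of carbon only), on a saturated chain carbon bound to an amide-type nitrogen. Within the data shown here, no measured pair follows this same change, so the size of the step is not anchored by a direct precedent.

The expectation for compound 3 is a move towards a lower number in this assay, of moderate size, because compound 2 with 1200 nM shows that the series reaches below compound 1. The estimated step from compound 1 to compound 3 is a 3.0-fold lower number from compound 1 to compound 3 (0.48 log units; beyond the scatter). Compound 3 is expected at 900 nM, with a range from 250 nM to 3500 nM.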

Compound 3, inhibition constant: 2040 nM
The estimate for compound 3 lay 2.3-fold (0.36 log units) below the measured number; the range from low to high includes it.
By their numbers in this assay, from the lowest: compounds 2, 3 and 1 (each within the scatter of the next, the first and the last beyond it).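

In this assay, placing the group of 9 heavy atoms (6 carbon, 3 nitrogen; one six-membered non-aromatic ring with 1 hetero atom) on the saturated chain carbon bound to an amide-type nitrogen, where compound 1 carries 4-(ethoxycarbonyl)cyclohexyl, gives a 1.3-fold lower number from compound 1 to compound 3 (0.13 log units; within the scatter). At this position, then, the two groups are not told apart by this read-out, even though they differ in ring type, in hetero atoms and in hydrogen-bond donors (2 against 0). No data at hand explain this result.

On these data alone, whether a carboxylic acid in place of the ethyl ester, or a primary amine on the same ring, would separate from compound 1 remains open. The compounds shown also leave open whether a longer chain between the amide nitrogen and the ring would alter the reading.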